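A few compounds are considered here, and "the series" means these few. Any claim that something is new, unique, unknown or untested is made for them only; others in the source may bear on it.

Of the compounds shown here, three have so far been measured in a functional assay on HepG2 cells (Homo sapiens) for inhibition, read by MTT assay, with a stated time of 72 h; on this read-out higher numbers stand for weaker inhibition and lower numbers for stronger inhibition. Compound 1, `COc1cc(/C=C/C(=O)c2c(OC)cc(O)c(CC=C(C)C)c2O)ccc1O`, gives 21700 nM in this assay. Compound 2, `COc1ccc(/C=C/C(=O)c2c(OC)cc(O)c(CC=C(C)C)c2O)cc1OC`, differs from compound 1 only by methyl in place of hydrogen on an oxygen on an aromatic ring, and in this assay compound 2 gives 13800 nM, which makes the step of a 1.6-fold lower number from compound 1 to compound 2 (0.20 log units; within the scatter). Compound 3, `COc1cc(O)cc(O)c1C(=O)/C=C/c1ccc(O)cc1`, rests on another core, and the difference between the two cores is not broken down here. In this assay compound 3 gives 40200 nM; its gap to compound 1 lies within the scatter of repeated measurements, while its gap to compound 2 lies beyond it.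

Compound 4, `COc1ccc(/C=C/C(=O)c2c(O)cc(O)cc2OC)cc1`, has not yet been measured in this assay. It differs from compound 3 by methyl in place of hydrogen on an oxygen on an aromatic ring, and since the place is described in the same words as for the change from compound 1 to compound 2, this is the same change carried out on the core of compound 3. Within the data shown here, the only measured instance of it is the step of a 1.6-fold lower number from compound 1 to compound 2 (0.20 log units; within the scatter), a step that stays within the scatter. On that single precedent, the expected step is a 1.4-fold lower number from compound 3 to compound 4 (0.16 log units; within the scatter), and its size rests on nothing more than that earlier step and the value of compound 3. Compound 4 is therefore estimated at 28000 nM in this assay, with an expected range from 12000 nM to 65000 nM.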

Compound 4, half-maximal inhibitory concentration: 18100 nM
Beside the measured number, compound 4's estimate is 1.5-fold (0.19 log units) above it, and the stated range covers the measured number.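

In this assay, methyl in place of hydrogen on an oxygen on an aromatic ring, the change from hydroxy to methoxy, gives a 2.2-fold lower number from compound 3 to compound 4 (0.35 log units; beyond the scatter) on the core of compound 3. Among these compounds, although only this step lies beyond the scatter, both instances run in the same direction, and their sizes cannot be told apart: the same change on two cores in this assay, a 1.6-fold lower number (0.20 log units; within the scatter) from compound 1 to compound 2 and a 2.2-fold lower number (0.35 log units; beyond the scatter) from compound 3 to compound 4, 1.4-fold (0.15 log units) apart, within the scatter of two such steps. In this series, the change therefore carries over between these two cores with no measurable difference in its size, but two pairs cannot establish a rule for other cores, and the measurements alone do not explain why the numbers move.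

The compounds shown leave open whether the step would hold on a third core, or on a core that differs from these two in some other place. They also leave open what this assay would show if the methyl on that oxygen gave way to a longer chain such as ethyl, or to a chain ending in an amine or a carboxylic acid.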